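The compounds below may be only part of what the source reports. "The series", "measured", "known", "first", "only" and "open" are said of these compounds alone.

Measured compounds:
- compound 1 `COc1ccccc1-c1nnc(-c2ccc(C(=O)N/N=C/c3ccc([N+](=O)[O-])cc3)cc2)o1`, 203000 nM in an ADME assay on THP-1 cells (Homo sapiens) for cytotoxicity; on this read-out higher numbers stand for weaker inhibition and lower numbers for stronger inhibition
- compound 2 `COc1ccccc1-c1nnc(-c2ccc(C(=O)N/N=C/c3cccc(O)c3)cc2)o1`, 398000 nM
- compound 3 `COc1ccccc1-c1nnc(-c2ccc(C(=O)N/N=C/c3cccnc3)cc2)o1`, 167000 nM

Compound 2 has the highest of the three numbers in this assay. The step of a 2.0-fold higher number from compound 1 to compound 2 (0.29 log units; within the scatter) is within the scatter, so those two cannot be separated, whereas the step of a 2.4-fold lower number from compound 2 to compound 3 (0.38 log units; beyond the scatter) is beyond it, if only modestly. Compound 4 `COc1ccccc1-c1nnc(-c2ccc(C(=O)N/N=C/c3c(O)cc(O)cc3O)cc2)o1` shares the core of compound 2 and differs from it in one place: 2,4,6-trihydroxyphenyl in place of 3-hydroxyphenyl on a carbon with a double bond to nitrogen. Going by the values given here, no measured step adds hydroxyl groups to a ring that already carries one; the steps at hand only swap the whole ring, and they are all small, the largest being a 2.4-fold lower number from compound 2 to compound 3 (0.38 log units; beyond the scatter). The 3-hydroxyphenyl ring of compound 2 gave a number no lower than those of compound 1 or compound 3, and the change to 2,4,6-trihydroxyphenyl keeps the same ring type while adding hydroxyl groups. Compound 4 is therefore expected to show a step of a 1.0-fold higher number from compound 2 to compound 4 (0.00 log units; within the scatter), essentially none beyond the scatter. Compound 4 is estimated at 400000 nM, with a range from 150000 nM to 1000000 nM.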

Compound 4, half-maximal inhibitory concentration: 12400 nM
Estimate against measurement, compound 4: 32-fold (1.51 log units) above; measured number outside the range, below it.
By their numbers in this assay, from the lowest: compound 4; then compounds 3, 1 and 2 (each within the scatter of the next, the first and the last beyond it).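

At the carbon with a double bond to nitrogen, the three earlier rings had moved the number in this assay only slightly, but this position can respond strongly: 2,4,6-trihydroxyphenyl gives a 32-fold lower number from compound 2 to compound 4 (1.51 log units; beyond the scatter), along with a 13-fold lower number from compound 3 to compound 4 (1.13 log units; beyond the scatter) and a 16-fold lower number from compound 1 to compound 4 (1.21 log units; beyond the scatter). Compound 4 therefore inhibits most strongly of the four, and the step from compound 2 shows that the ring type alone does not set the number, since both compounds carry a six-membered aromatic ring of carbon only and differ in their hydroxyl groups. Nothing available here explains the size of this step. Going by these compounds, it remains open whether a dihydroxyphenyl ring would already give part of the step. On these data alone, it is also open whether methoxy or amino groups in place of these hydroxyl groups would give a similar number.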